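A few compounds are considered here, and "the series" means these few. Any claim that something is new, unique, unknown or untested is made for them only; others in the source may bear on it.

Measured compounds:
- Compound 1, `COc1cc2c(=O)c(C(=O)c3ccc(C)cc3)cn(CC3CCCCC3)c2cc1OC`, gives 22000 nM in an ADME assay on Huh-7 cells (Homo sapiens) for cytotoxicity; a lower number here means a stronger inhibitor of growth, a higher number a weaker inhibitor of growth.
- Compound 2, `COc1cc2c(=O)c(C(=O)c3ccc(C)cc3)cn(Cc3ccc(C(F)(F)F)cc3F)c2cc1OC`, reaches only a limit of the assay, > 25000 nM, in this assay.

Compound 2 therefore stands at the upper edge of what this assay reports: its value is a limit, not a number, and it is the one result of the two that sits at the limit of > 25000 nM in this assay, at which 1 of the 2 values shown sits. Among the measured compounds shown here, the single measured step, an at least 1.1-fold higher number from compound 1 to compound 2 (0.05 log units; that floor lies within the scatter), is read from a number to a limit and its floor lies within the scatter, so it shows no change beyond what repeat measurements would give.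

Compound 3, `COc1cc2c(=O)c(C(=O)c3ccc(C)cc3)cn(Cc3ccc(Cl)c(Cl)c3)c2cc1OC`, differs from compound 2 by 3,4-dichlorophenyl in place of 2-fluoro-4-(trifluoromethyl)phenyl on a saturated chain carbon bound to an aromatic nitrogen. For the measured compounds named here, the only measured step concerns the same place on the shared core and was at most a small move, ending in a limit. Nothing measured points to a large change in either direction, so compound 3 is expected to stay near the limit in this assay, with a step of about a number no higher from compound 2 to compound 3 (the limit leaves the size open). Compound 3 is estimated at 25000 nM, between 9000 nM and 60000 nM.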

Compound 3, concentration for 50% growth inhibition: "not active" (no number reported)
Compound 3: no number reported; no gap can be computed for the estimate.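

In this assay, compound 3 is reported only as "not active", with no number. Compound 2 gives > 25000 nM, which is a limit, so no step can be read between compound 2 and compound 3. The compounds shown leave open whether changing the group at this place on the shared core alters growth inhibition at all.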